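Replacing the furan-2-yl group of compound 2

This account rests on a few compounds, and the source may have more. Where it says the series, first, only, none or still open, it means among the compounds named here.

Measured in a functional assay on SMMC-7721 cells (Homo sapiens) for antiproliferative activity, read by MTT assay, with a stated time of 72 h; a lower number here means a stronger inhibitor, a higher number a weaker inhibitor:
- compound 1 `C/C(=N\NC(=O)c1cccc(S(=O)(=O)N2CCOCC2)c1)c1ccc(F)cc1` gives > 100000 nM
- compound 2 `O=C(N/N=C/c1ccco1)c1cccc(S(=O)(=O)N2CCOCC2)c1` gives > 100000 nM

Compound 2 stands at > 100000 nM in this assay, and this is a limit of the assay rather than a number. So far the record holds only (the limit of > 100000 nM in this assay, at which 2 of the 2 values shown sit). Compound 3 `O=C(N/N=C/c1cc(Br)ccc1O)c1cccc(S(=O)(=O)N2CCOCC2)c1` differs from compound 2 in one place: 5-bromo-2-hydroxyphenyl in place of furan-2-yl on a carbon with a double bond to nitrogen. For the measured compounds named here, no measured step gives a size to go by, so this is a cautious expectation of a gain in this assay, towards a lower number, though another limit remains possible. The expected change is an at least 4.0-fold lower number from compound 2 to compound 3 (0.60 log units; beyond the scatter). For compound 3 the estimate is 25000 nM, with an expected range from 4000 nM to 100000 nM.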

Compound 3, half-maximal inhibitory concentration: 9940 nM
Compound 3: middle estimate off by 2.5-fold (0.40 log units), on the high side; measured number inside the range.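

In this assay, the group on the carbon with a double bond to nitrogen proves able to shift the result: 5-bromo-2-hydroxyphenyl in place of furan-2-yl gives an at least 10-fold lower number from compound 2 to compound 3 (1.00 log units; beyond the scatter) at this position. For the compounds shown here, compound 3 is the first compound here with a real number rather than a limit. As far as these compounds go, the true size of the step remains unknown, as its starting point is only a limit: the limit of > 100000 nM in this assay, at which 2 of the 3 values shown sit.

This single change swaps the ring and brings in both bromine and hydroxy, so the compounds shown do not separate their contributions. From the compounds shown here alone, whether an unsubstituted phenyl, or an amine in place of the hydroxy, would keep the gain remains open.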